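The source may hold more compounds than are shown below. What is called first, only, known or untested is meant among the compounds shown, and "the series" means these compounds.

Compound 1 `CN(C)CCCNc1ccc(S(=O)(=O)NC(=O)c2ccc(N3CCN(CC4=C(c5ccc(C(F)(F)F)cc5)CC(C)(C)CC4)CC3)cc2Oc2cnc3[nH]ccc3c2)cc1[N+](=O)[O-]` gives 0.89 nM in an assay on isolated protein for displacement of a labelled ligand from Apoptosis regulator Bcl-2 (Homo sapiens), with a stated time of 15 min (on this read-out higher numbers stand for weaker inhibition and lower numbers for stronger inhibition), the lowest of the three numbers recorded. Compound 2 `CC1(C)CCC(CN2CCN(c3ccc(C(=O)NS(=O)(=O)c4ccc(OCC5CCOCC5)c([N+](=O)[O-])c4)c(Oc4cnc5[nH]ccc5c4)c3)CC2)=C(c2ccc(C(F)(F)F)cc2)C1` gives 1 nM in this assay, and compound 3 `CC(Oc1ccc(S(=O)(=O)NC(=O)c2ccc(N3CCN(CC4=C(c5ccc(C(F)(F)F)cc5)CC(C)(C)CC4)CC3)cc2Oc2cnc3[nH]ccc3c2)cc1[N+](=O)[O-])C1CCOCC1` gives 9.2 nM. The step of a 1.1-fold higher number from compound 1 to compound 2 (0.05 log units; within the scatter) bears most directly on compound 4 `CCN1CCC(COc2ccc(S(=O)(=O)NC(=O)c3ccc(N4CCN(CC5=C(c6ccc(C(F)(F)F)cc6)CC(C)(C)CC5)CC4)cc3Oc3cnc4[nH]ccc4c3)cc2[N+](=O)[O-])CC1`, which differs from compound 1 by (1-ethylpiperidin-4-yl)methoxy in place of (3-(dimethylamino)propyl)amino on an aromatic carbon. The step of a 9.2-fold higher number from compound 2 to compound 3 (0.96 log units; beyond the scatter) shows that a methyl added on the chain carbon can matter, yet compound 4 keeps that carbon unsubstituted, as in compound 2. Since the exchange of the amine chain for a ring-bearing ether left the number where it stood in the step from compound 1 to compound 2, compound 4 is expected to move by a 1.3-fold higher number from compound 1 to compound 4 (0.13 log units; within the scatter), with an estimated value of 1.2 nM and a range from 0.5 nM to 3 nM.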

Compound 4, half-maximal inhibitory concentration: 0.5 nM
For compound 4 the middle estimate is 2.4-fold (0.38 log units) above the measured one; the measured number falls inside the stated range.
By their numbers in this assay, from the lowest: compounds 4, 1 and 2 (each within the scatter of the next); then compound 3.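

At this position, ortho to a nitro group, a 1.8-fold lower number from compound 1 to compound 4 (0.25 log units; within the scatter) shows in this assay that a ring-bearing ether with a nitrogen in its ring sits level with the open amine chain. Exchanging oxan-4-yl for 1-ethylpiperidin-4-yl gives a 2.0-fold lower number from compound 2 to compound 4 (0.30 log units; within the scatter) and so also leaves the number unmoved, whereas an 18-fold lower number from compound 3 to compound 4 (1.26 log units; beyond the scatter) is a large step that changes the ring and removes the chain methyl together. Nothing measured here explains these steps.

Open, from the compounds shown here alone, is whether a morpholine or a primary amine would hold this level, and whether the chain methyl acts the same on the 1-ethylpiperidin-4-yl ether.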